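This account rests on a few compounds, and the source may have more. Where it says the series, first, only, none or still open, it means among the compounds named here.

Compound 1 `CCCC(=O)CC1C(C(=O)OCC)=C(N)Oc2ccc(-c3cc(OC)cc(OC)c3)cc21` and compound 2 `CCOC(=O)CC1C(C(=O)OCC)=C(N)Oc2ccc(-c3cc(OC)cc(OC)c3)cc21` share one core and differ at a single carbonyl carbon. In a functional assay on HL60/MX2 cells (Homo sapiens) for inhibition, with a stated time of 48 h (a lower number here means a stronger inhibitor, a higher number a weaker inhibitor), compound 1 gives 11700 nM, while compound 2 gives 1700 nM. Among the compounds with values here, that step, a 6.9-fold lower number from compound 1 to compound 2 (0.84 log units; beyond the scatter), came from putting ethoxy in place of propyl on the carbonyl carbon, and it leaves compound 2 with the lowest of the two numbers measured so far. Compound 3 `CCOC(=O)C1=C(N)Oc2ccc(-c3cc(OC)cc(OC)c3)cc2C1CC(=O)c1ccccc1` changes the same carbonyl carbon once more: phenyl in place of ethoxy on a carbonyl carbon. Within the data shown here, only the step from compound 1 to compound 2 bears on this change, and it pointed the other way, trading a carbon group for ethoxy and lowering the number. Taking ethoxy away again, this time for phenyl, is therefore expected to raise the number, though phenyl is not propyl and the size is uncertain. Compound 3 is expected to give about 4500 nM in this assay, somewhere between 1500 nM and 14000 nM. That estimate corresponds to an expected 2.6-fold higher number from compound 2 to compound 3 (0.42 log units; beyond the scatter).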

Compound 3, half-maximal inhibitory concentration: 41000 nM
For compound 3 the middle estimate is 9.1-fold (0.96 log units) below the measured one, outside the stated range (above it).
By their numbers in this assay, from the lowest: compound 2; then compound 1; then compound 3.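

In this assay, replacing ethoxy with phenyl on this carbonyl carbon gives a 24-fold higher number from compound 2 to compound 3 (1.38 log units; beyond the scatter), a large step where the earlier change at the same carbon was modest. The two carbon groups also do not behave alike: phenyl in place of propyl gives a 3.5-fold higher number from compound 1 to compound 3 (0.54 log units; beyond the scatter), so compound 3 has the highest number of the three, and ethoxy in compound 2 gives the lowest. No measurement shown explains why these groups differ.

The compounds shown leave open whether a smaller oxygen-linked group such as methoxy would keep the low number of compound 2, and whether an amine on this carbonyl carbon would track ethoxy or the carbon groups. They also leave open whether a substituted phenyl would lower the number of compound 3.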